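The compounds below may be only part of what the source reports. "The series", "measured", "known", "first", "only" and "open" are said of these compounds alone.

Of the compounds shown here, three sharing one core have been measured in a physicochemical assay for solubility, read by HPLC, using the shake flask method, measured as kinetic solubility, with a stated time of 2 h, at pH 7.4; a higher number here means a more soluble compound, a lower number a less soluble compound. Compound 1 `Cc1cc(NCc2ccccn2)n2nc(C)c(-c3ccc(F)cc3)c2n1` gives < 5000 nM, which is a limit rather than a number. Compound 2 `Cc1cc(NCc2cccs2)n2nc(C)c(-c3ccccc3)c2n1` likewise gives < 5000 nM, again a limit. Compound 3 `Cc1cc(NCc2ccccn2)n2ncc(-c3cccc(Cl)c3)c2n1` also gives < 5000 nM, a limit. On the numbers shown, compound 3 stands nowhere apart from the others, since every value rests at the limit of < 5000 nM in this assay, at which 3 of the 3 values shown sit. For the measured compounds named here, no step between measured compounds can be read from these data. Compound 4 `Cc1cc(NCc2ccccn2)n2ncc(-c3ccn(C)n3)c2n1` differs from compound 3 in one place: 1-methyl-1H-pyrazol-3-yl in place of 3-chlorophenyl on an aromatic carbon. Going by the values given here, with only limits known, no measured step guides the expectation, yet an upward move in this assay is expected for compound 4, amounting to an at least 3.0-fold higher number from compound 3 to compound 4 (0.47 log units; beyond the scatter). Compound 4 is therefore estimated at 15000 nM, with a range from 3000 nM to 60000 nM.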

Compound 4, solubility: 188000 nM
Estimate against measurement, compound 4: 13-fold (1.10 log units) below, and the stated range ends below it.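

For the compounds shown here, this aromatic carbon is the first place where a change of group is seen to move the read-out in this assay: 1-methyl-1H-pyrazol-3-yl in place of 3-chlorophenyl gives an at least 37-fold higher number from compound 3 to compound 4 (1.57 log units; beyond the scatter). That figure is only the smallest size the step can have, and compound 4 alone gives a number rather than a limit: the limit of < 5000 nM in this assay, at which 3 of the 4 values shown sit.

The change replaces a six-membered carbon ring with a five-membered ring holding two nitrogens, and the compounds shown do not separate these features. Going by these compounds, whether an amine or a carboxylic acid on this carbon would give a similar number remains open.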